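The compounds below may be only part of what the source reports. "The series", "measured", "known", "first", "only" and "open" are said of these compounds alone.

Measured in a functional assay on HepG2 cells (Homo sapiens) for cytotoxicity, read by MTT assay, with a stated time of 24 h; on this read-out higher numbers stand for weaker inhibition and lower numbers for stronger inhibition:
- compound 1 `COc1cc(/C=C2\CN(C)C/C(=C\c3ccc(Br)cc3)C2=O)cc(OC)c1`: 4840 nM
- compound 2 `COc1cc(/C=C2\CN(C)C/C(=C\c3ccc(Cl)cc3Cl)C2=O)cc(OC)c1`: 6250 nM
- compound 3 `COc1cc(/C=C2\CN(C)C/C(=C\c3ccc(C#N)cc3)C2=O)cc(OC)c1`: 880 nM

Among these, compound 3 gives the lowest number, and its separation from both others lies beyond the scatter: a 5.5-fold lower number from compound 1 to compound 3 (0.74 log units; beyond the scatter) and a 7.1-fold lower number from compound 2 to compound 3 (0.85 log units; beyond the scatter). Compound 4 `COc1cc(/C=C2\CN(C)C/C(=C\c3ccc(C#N)cc3)C2=O)cc(OC)c1OC` differs from compound 3 in one place, with methoxy in place of hydrogen on an aromatic carbon, ortho to two methoxy groups and para to a large group: methoxy in place of hydrogen on an aromatic carbon.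

For the measured compounds named here, none of the measured steps changes the ring that carries the methoxy groups. All of them concern the other aromatic ring, so they bear on this change only indirectly. They show what a single exchange has done elsewhere in the series: a 1.3-fold higher number from compound 1 to compound 2 (0.11 log units; within the scatter) stayed within the scatter, while a 5.5-fold lower number from compound 1 to compound 3 (0.74 log units; beyond the scatter) was modest. With no direct evidence for a direction, no change beyond the scatter is expected. The expected outcome is a 1.2-fold lower number from compound 3 to compound 4 (0.07 log units; within the scatter). In this assay, the estimate for compound 4 is 750 nM, with an expected range from 220 nM to 2500 nM.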

Compound 4, half-maximal inhibitory concentration: 1140 nM
Compound 4: middle estimate off by 1.5-fold (0.18 log units), on the low side; low and high end bracket the measured number.
By their numbers in this assay, from the lowest: compounds 3 and 4 (each within the scatter of the next); then compounds 1 and 2 (each within the scatter of the next).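

For the compounds shown here, the earlier compounds varied only the other aromatic ring, so this is the first reading on the ring that carries the methoxy groups. In this assay, methoxy in place of hydrogen on an aromatic carbon, ortho to two methoxy groups and para to a large group, gives a 1.3-fold higher number from compound 3 to compound 4 (0.11 log units; within the scatter), so with 4-cyanophenyl on the other side, this carbon takes a methoxy group without a separation beyond the scatter. Nothing measured alongside these numbers offers an explanation for this result.

As far as these compounds go, whether a different group on this carbon, such as an amine, a hydroxyl or a longer chain like ethoxy, would stay within the scatter remains open. So does whether the same methoxy exchange would give a similar step with the 4-bromophenyl of compound 1 or the 2,4-dichlorophenyl of compound 2.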